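Swapping the aryl group on the ketone of a weak cytotoxic core

A few compounds are considered here, and "the series" means these few. Any claim that something is new, unique, unknown or untested is made for them only; others in the source may bear on it.

Measured compounds:
- compound 1, `COc1cc(-c2nnc3n2NC(c2ccco2)C(C(=O)c2ccccc2)S3)cc(OC)c1OC`, 90900 nM
- compound 2, `COc1cc(-c2nnc3n2NC(c2ccco2)C(C(=O)c2ccc(F)c(F)c2)S3)cc(OC)c1OC`, 52400 nM

Both numbers come from a functional assay on HepG2 cells (Homo sapiens) for cytotoxicity, read by MTT assay, with a stated time of 48 h; on this read-out higher numbers stand for weaker inhibition and lower numbers for stronger inhibition. Compound 1 and compound 2 share the same core and differ only in the aryl group attached to the carbonyl carbon. The step of a 1.7-fold lower number from compound 1 to compound 2 (0.24 log units; within the scatter) is too small to count as a real change, so the two compounds can only be said to sit in the same region of weak inhibition. On the numbers shown, compound 2 has the lowest value of the two, but that nearest neighbour, compound 1, lies within the scatter of it.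

Compound 3, `COc1cc(-c2nnc3n2NC(c2ccco2)C(C(=O)c2ccc(C(F)(F)F)cc2)S3)cc(OC)c1OC`, is the next compound in this series. Its change from compound 2 is 4-(trifluoromethyl)phenyl in place of 3,4-difluorophenyl on a carbonyl carbon. Within the data shown here, the only step measured so far, from compound 1 to compound 2, also changed the aryl group on the carbonyl carbon and stayed within the scatter, so it is the only guide, and it points to no marked effect from altering this part of the molecule. For compound 3 the step of a 1.0-fold lower number from compound 2 to compound 3 (0.02 log units; within the scatter) is therefore expected to stay within the scatter. Compound 3 is estimated to give 50000 nM in this assay, with a range of 20000 nM to 130000 nM.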

Compound 3, half-maximal inhibitory concentration: > 100000 nM
Compound 3 gave a limit, no number (the forecaster's own chance of this, stated with the estimate: 20%); middle value at least 2.0-fold (0.30 log units) away from the limit.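

In this assay compound 3 gives > 100000 nM, which is a limit of the assay and not a number. Set against the two neighbouring compounds, the result reads as an at least 1.9-fold higher number from compound 2 to compound 3 (0.28 log units; that floor lies within the scatter) and as an at least 1.1-fold higher number from compound 1 to compound 3 (0.04 log units; that floor lies within the scatter), the second being the plain exchange of trifluoromethyl for hydrogen on an aromatic carbon, and neither floor shows a real change at this position. What compound 3 adds is a third aryl group on the carbonyl carbon, 4-(trifluoromethyl)phenyl, and a first reading at this position that reaches the end of the measurable range: the limit of > 100000 nM in this assay, at which 1 of the 3 values shown sits.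

The compounds shown leave open whether any group on the carbonyl carbon can move the reading beyond the scatter, since the aromatic rings here carry only hydrogen, fluorine or trifluoromethyl. An amine or a carboxylic acid on that aromatic ring, or a longer alkyl chain in place of the ring, would test whether this position matters at all for the cytotoxicity of the shared core.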